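The source may report more compounds than this note shows. Statements on the series, on what has been measured and on what is new or still open speak of the compounds shown alone.

Compound 3 `N[C@]1(C(=O)O)[C@H]2[C@@H](C[C@H]1OCc1cccc(F)c1F)[C@]2(F)C(=O)O` stands second highest of the three numbers in an assay on CHO cells for binding affinity to metabotropic glutamate receptor 2 (Rattus norvegicus) (on this read-out lower numbers stand for stronger inhibition and higher numbers for weaker inhibition), where compound 3 gives 4.25 nM. Its nearest neighbour is compound 2 `N[C@]1(C(=O)O)[C@H]2[C@@H](C[C@H]1OCc1cccc(Br)c1)[C@]2(F)C(=O)O`, which in this assay gives 4.71 nM, and its furthest is compound 1 `N[C@]1(C(=O)O)[C@H]2[C@@H](C[C@H]1OCc1cccc(Cl)c1)[C@]2(F)C(=O)O`, which gives 3.28 nM. Compound 4 `N[C@]1(C(=O)O)[C@H]2[C@@H](C[C@H]1OCc1c(Cl)cccc1Cl)[C@]2(F)C(=O)O` differs from compound 3 by 2,6-dichlorophenyl in place of 2,3-difluorophenyl on a saturated chain carbon bound to an oxygen on a saturated carbon. The measured steps that bear on this are exchanges of halogens on the same phenyl ring: a 1.4-fold higher number from compound 1 to compound 2 (0.16 log units; within the scatter), a 1.3-fold higher number from compound 1 to compound 3 (0.11 log units; within the scatter) and a 1.1-fold lower number from compound 2 to compound 3 (0.04 log units; within the scatter), each within the scatter. For the measured compounds named here, no measured step covers the 2,6-dichlorophenyl pattern itself, so the expectation rests on those three. Compound 4 is therefore expected to show a 1.3-fold higher number from compound 3 to compound 4 (0.11 log units; within the scatter), with an estimated 5.5 nM and a range from 2 nM to 16 nM.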

Compound 4, inhibition constant: 4.3 nM
Compound 4: middle estimate off by 1.3-fold (0.11 log units), on the high side, and the stated range covers the measured number.
By their numbers in this assay, from the lowest: compounds 1, 3, 4 and 2 (each within the scatter of the next).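

In this assay the 2,6-dichlorophenyl group stays within the scatter of all three earlier rings (a 1.0-fold higher number from compound 3 to compound 4 (0.01 log units; within the scatter)) and (a 1.1-fold lower number from compound 2 to compound 4 (0.04 log units; within the scatter)) and (a 1.3-fold higher number from compound 1 to compound 4 (0.12 log units; within the scatter)). At this place, on a saturated chain carbon bound to an oxygen on a saturated carbon, a phenyl ring with two chlorines therefore fits the same narrow band of numbers as the rings with one or two other halogens. Nothing available explains this sameness.

As far as these compounds go, all four compounds carry a halogenated phenyl ring, so an amine or a carboxylic acid on that ring remains open, as does a longer chain in its place.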